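Moving the fluorine on the benzyl ring of compound 3

The source may hold more compounds than are shown below. What is called first, only, known or untested is meant among the compounds shown, and "the series" means these compounds.

Compound 3 `Nc1ccc(/C=C2\SC(=O)N(Cc3cccc(F)c3)C2=O)cc1` and compound 1 `CC(C)(C)c1ccc(CN2C(=O)S/C(=C\c3ccc(N)cc3)C2=O)cc1` share one core with a 4-aminophenyl group. In a functional assay on FM3A cells (Mus musculus) for cytotoxicity, read by cell counting, with a stated time of 2 days (a higher number here means a weaker inhibitor, a lower number a stronger inhibitor), compound 3 gives 121000 nM, the larger of the two numbers reported, though its gap to compound 1, which gives 80000 nM, lies within the scatter. In this assay compound 2 `Nc1cccc(/C=C2\SC(=O)N(Cc3cccc(F)c3)C2=O)c1` gives > 250000 nM, which is a limit of the assay and not a number, as the limit of > 250000 nM in this assay, at which 1 of the 3 values shown sits, records. Among the measured compounds shown here, the only measured step, an at least 2.0-fold lower number from compound 2 to compound 3 (0.31 log units; beyond the scatter), concerns the aminophenyl ring rather than the benzyl group. Compound 4 `Nc1ccc(/C=C2\SC(=O)N(Cc3ccc(F)cc3)C2=O)cc1` differs from compound 3 by 4-fluorophenyl in place of 3-fluorophenyl on a saturated chain carbon bound to an amide-type nitrogen in a ring. For the measured compounds named here, no measured step touches this change, so a shift within the scatter is expected, a 1.1-fold lower number from compound 3 to compound 4 (0.04 log units; within the scatter), and compound 4 is estimated at 110000 nM, between 45000 nM and 250000 nM.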

Compound 4, half-maximal inhibitory concentration: 36000 nM
For compound 4 the middle estimate is 3.1-fold (0.49 log units) above the measured one, outside the stated range (below it).
By their numbers in this assay, from the lowest: compound 4; then compounds 1 and 3 (each within the scatter of the next). At a limit, above all of these: compound 2.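

In this assay the place of the fluorine on the benzyl ring proves to matter: 4-fluorophenyl in place of 3-fluorophenyl, with the same atoms on both sides, gives a 3.4-fold lower number from compound 3 to compound 4 (0.53 log units; beyond the scatter). Until now, only a change on the aminophenyl ring had given a step beyond the scatter. Fluoro in place of tert-butyl on an aromatic carbon also gives a 2.2-fold lower number from compound 1 to compound 4 (0.35 log units; beyond the scatter), so the identity of the benzyl substituent registers here too.

Going by these compounds, whether a chloro or methoxy group on the benzyl ring would behave as the fluoro does remains open. Nothing shown accounts for either step.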